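From an Ester Chain to a Phenylsulfanyl Chain

The source may hold more compounds than are shown below. What is called first, only, known or untested is meant among the compounds shown, and "the series" means these compounds.

In a functional assay (trachea) with Cavia porcellus as the target (on this read-out lower numbers stand for stronger inhibition and higher numbers for weaker inhibition), compound 2 (`CCOC(=O)CCCn1nc(-c2cccnc2)c2ccccc2c1=O`) holds the highest of the two numbers at 10000 nM, while compound 1 (`O=c1c2ccccc2c(-c2cccnc2)nn1Cc1ccccc1`) gives 2450 nM. Compound 3 (`O=c1c2ccccc2c(-c2cccnc2)nn1CCSc1ccccc1`) differs from compound 2 as follows: phenylsulfanyl in place of (ethoxycarbonyl)methyl on a saturated chain carbon, two bonds along the chain from an aromatic nitrogen. Within the data shown here, one measured step bears on this, the modest 4.1-fold higher number from compound 1 to compound 2 (0.61 log units; beyond the scatter), where 2-(ethoxycarbonyl)ethyl took the place of phenyl. Compound 3 again carries a phenyl ring, so a move back towards compound 1 at 2450 nM is expected, of similar or smaller size. The expected change is a 2.9-fold lower number from compound 2 to compound 3 (0.46 log units; beyond the scatter). For compound 3 the estimated value is 3500 nM, within an expected range of 1200 nM to 10000 nM.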

Compound 3, half-maximal inhibitory concentration: 9120 nM
For compound 3 the middle estimate is 2.6-fold (0.42 log units) below the measured one, and the stated range covers the measured number.
By their numbers in this assay, from the lowest: compound 1; then compounds 3 and 2 (each within the scatter of the next).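

In this assay, the exchange of the ester for phenylsulfanyl on this chain gives a 1.1-fold lower number from compound 2 to compound 3 (0.04 log units; within the scatter), so the two chains cannot be told apart here. A phenyl ring at the end of a longer chain thus does not recover the number of compound 1, as the step of a 3.7-fold higher number from compound 1 to compound 3 (0.57 log units; beyond the scatter) stands beyond the scatter. Nothing measured here explains this result.

From the compounds shown here alone, it remains open whether an amine or a carboxylic acid at the chain end would change the number. The compounds shown also leave open how a phenyl ring on a chain without sulfur would behave.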